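Swapping one halogenated phenyl for another on the ring amine

The source may hold more compounds than are shown below. What is called first, only, known or untested is meant among the compounds shown, and "the series" means these compounds.

Compound 2 `Nc1scc(CN2CCN(c3ccc(F)c(F)c3)CC2)c1C(=O)c1ccc(Cl)cc1` carries the lower of the two numbers recorded so far: in a functional assay on CHO cells with adenosine receptor A1 (Homo sapiens) as the target, read by cAMP accumulation and immunoassay, with a stated time of 6 min, tested at 10 uM (a lower number here means a stronger effect, a higher number a weaker effect of the compound at the concentration tested), compound 2 gives -87%, while compound 1 `CC(C)N1CCN(Cc2csc(N)c2C(=O)c2ccc(Cl)cc2)CC1` gives -7.4%. Compound 3 `Nc1scc(CN2CCN(c3cc(Cl)ccc3Cl)CC2)c1C(=O)c1ccc(Cl)cc1` differs from compound 2 in one place: 2,5-dichlorophenyl in place of 3,4-difluorophenyl on an amine nitrogen in a ring. Within the data shown here, the only measured step, a number 79.6 percentage points lower from compound 1 to compound 2 (beyond the scatter), concerns the same position, but it exchanges a small alkyl group for an aromatic ring, a far bigger change than moving from one dihalophenyl to another. Among the measured compounds shown here, no measured step compares two aromatic groups at this position, so the effect of the present change is uncertain. A step of a number 12 percentage points higher from compound 2 to compound 3 (beyond the scatter) is expected, within or only modestly beyond the scatter and, if anything, toward a weaker effect. Compound 3 is therefore estimated at -75%, within the range -100% to -40%.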

Compound 3, a percentage reported as activity, at one concentration (the size of the read-out at that concentration, not a potency): -62%
Compound 3: middle estimate off by 13 percentage points, on the low side, within the range that was stated.
By their numbers in this assay, from the lowest: compound 2; then compound 3; then compound 1.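

Two aromatic groups can now be compared at this position on the amine nitrogen. In this assay there is a number 25 percentage points higher from compound 2 to compound 3 (beyond the scatter), so the outcome depends on which dihalophenyl group is present, not only on having an aromatic ring there. The 2,5-dichlorophenyl group still keeps most of the drop seen with the 3,4-difluorophenyl group, with a number 54.6 percentage points lower from compound 1 to compound 3 (beyond the scatter), and nothing available explains why the two halogenated groups differ.

Compound 2 and compound 3 differ in both the halogen and where it sits on the ring, so the shown compounds cannot say which of the two accounts for the step, and a 3,4-dichlorophenyl group would help separate them. Also open, on these data alone, is whether a plain phenyl group would fall with compound 2 and compound 3 or nearer compound 1.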